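The source may hold more compounds than are shown below. What is called first, only, known or untested is meant among the compounds shown, and "the series" means these compounds.

The compounds share one core and differ only in the group attached to a saturated chain carbon bound to an aromatic nitrogen. Compound 1 `COc1ccc(-c2nn(-c3ccccc3)cc2C(=O)NCc2cn(Cc3ccc(F)cc3)nn2)cc1` carries a 4-fluorobenzyl group there, and in a functional assay on MIA PaCa-2 cells (Homo sapiens) for antiproliferative activity, read by sulforhodamine B assay, with a stated time of 48 h (a lower number here means a stronger inhibitor of growth, a higher number a weaker inhibitor of growth), compound 1 gives 24100 nM. Compound 2 `COc1ccc(-c2nn(-c3ccccc3)cc2C(=O)NCc2cn(Cc3ccc(Cl)cc3)nn2)cc1` carries a 4-chlorobenzyl group; in this assay compound 2 gives 26300 nM, and a 1.1-fold higher number from compound 1 to compound 2 (0.04 log units; within the scatter). Compound 3 `COc1ccc(-c2nn(-c3ccccc3)cc2C(=O)NCc2cn(Cc3ccc(C(F)(F)F)cc3)nn2)cc1` carries a 4-(trifluoromethyl)benzyl group, and for compound 3 this assay reports only a limit, > 100000 nM. The two steps into compound 3, an at least 4.1-fold higher number from compound 1 to compound 3 (0.61 log units; beyond the scatter) and an at least 3.8-fold higher number from compound 2 to compound 3 (0.58 log units; beyond the scatter), make compound 3 the weakest inhibitor among the three measured.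

Compound 4 `COc1ccc(-c2nn(-c3ccccc3)cc2C(=O)NCc2cn(Cc3ccc(OC)c(OC)c3)nn2)cc1` alters the same group: 3,4-dimethoxyphenyl in place of 4-(trifluoromethyl)phenyl on a saturated chain carbon bound to an aromatic nitrogen. Among the measured compounds shown here, no measured step swaps a trifluoromethyl group for methoxy groups, so the halogen-to-trifluoromethyl steps bear on this change only loosely; they show merely that the trifluoromethyl group went with the weakest inhibition. A partial return toward the halogen compounds is expected, though compound 3 stands at a limit and the step can only be estimated roughly. The expected step is an at least 2.2-fold lower number from compound 3 to compound 4 (0.34 log units; beyond the scatter). Compound 4 is estimated at 45000 nM, within a range from 15000 nM to 130000 nM.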

Compound 4, concentration for 50% growth inhibition: 16300 nM
Compound 4: middle estimate off by 2.8-fold (0.44 log units), on the high side; the measured number falls inside the stated range.
By their numbers in this assay, from the lowest: compounds 4, 1 and 2 (each within the scatter of the next). At a limit, above all of these: compound 3.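

Putting 3,4-dimethoxyphenyl in place of 4-(trifluoromethyl)phenyl on a saturated chain carbon bound to an aromatic nitrogen recovers growth inhibition in this assay, with an at least 6.1-fold lower number from compound 3 to compound 4 (0.78 log units; beyond the scatter). Set against the halogen compounds, the same group gives a 1.6-fold lower number from compound 2 to compound 4 (0.21 log units; within the scatter) and a 1.5-fold lower number from compound 1 to compound 4 (0.17 log units; within the scatter), so among these four compounds the position tolerates 3,4-dimethoxyphenyl as well as 4-fluorophenyl and 4-chlorophenyl, and only compound 3 falls away. Compound 3 is reported only as a limit, so the step out of it gives a minimum size and not an exact one: the limit of > 100000 nM in this assay, at which 1 of the 4 values shown sits.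

The compounds shown cannot tell whether a single methoxy group would match the 3,4-dimethoxyphenyl group. They also leave open how an amine, a carboxylic acid or a longer chain would fare at this position.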